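The compounds below may be only part of what the source reports. "The series", "measured", "known", "first", "only" and "open" are said of these compounds alone.

Among the compounds with values here, in an ADME assay on ECV-304 cells (Homo sapiens) for cytotoxicity, read by MTT assay, with a stated time of 72 h (a lower number here means a stronger inhibitor, a higher number a weaker inhibitor), compound 2 `COc1ccc(OC)c(C2=C(c3cc(OC)c(OC)c(OC)c3)C(=O)CC2O[SiH2]C(C)(C)C)c1` gives 6.5 ug/mL, the lower of the two true numbers so far. Compound 1 `COc1ccc(C2=C(c3cc(OC)c(OC)c(OC)c3)C(=O)C(OC(C)=O)C2)cc1` gives 18 ug/mL. Compound 3 `COc1ccc(OC)c(C2=C(c3cc(OC)c(OC)c(OC)c3)C(=O)CC2O)c1` reads > 100 ug/mL, which is a limit of the assay and not a number. Within the data shown here, the only measured step, an at least 15-fold higher number from compound 2 to compound 3 (1.18 log units; beyond the scatter), put a hydrogen atom in place of the silicon-bearing group on an oxygen. Compound 4 `COCOc1cc(C2=C(c3cc(OC)c(OC)c(OC)c3)C(=O)CC2O[SiH2]C(C)(C)C)ccc1OC` keeps that group and instead changes the group on a double-bonded ring carbon: 4-methoxy-3-(methoxymethoxy)phenyl in place of 2,5-dimethoxyphenyl on a double-bonded ring carbon. Among the measured compounds shown here, no measured step covers this swap, so the large step offers no guide, and only a small rise, not clearly beyond the scatter, is expected in this assay. The estimated move is a 1.5-fold higher number from compound 2 to compound 4 (0.19 log units; within the scatter). For compound 4 the expected value is 10 ug/mL, within 3.5 ug/mL to 30 ug/mL.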

Compound 4, half-maximal inhibitory concentration: 40 ug/mL
Beside the measured number, compound 4's estimate is 4.0-fold (0.60 log units) below it; the measured number lies above the stated range.
By their numbers in this assay, from the lowest: compound 2; then compound 1; then compound 4. At a limit, above all of these: compound 3.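

The group on the double-bonded ring carbon matters in this assay: with the silicon-bearing group kept on the oxygen, 4-methoxy-3-(methoxymethoxy)phenyl in place of 2,5-dimethoxyphenyl gives a 6.2-fold higher number from compound 2 to compound 4 (0.79 log units; beyond the scatter) as the step. The earlier compounds had shown a measured change only at that oxygen, so this is a second place where the number responds. Nothing shown bears on why the number rose.

Because both ring groups differ in more than one way, the step cannot say which difference counts. On these data alone, how a phenyl group carrying an amine or a carboxylic acid would read at this place also stays open.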